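Bromo to ethyl on the shared core

The compounds below may be only part of what the source reports. "The series", "measured", "known", "first", "only" and "open" are said of these compounds alone.

Within the data shown here, in a functional assay on NFS-60 cells (Mus musculus) for inhibition, with a stated time of 72 h (a lower number here means a stronger inhibitor of growth, a higher number a weaker inhibitor of growth), compound 1 `Nc1ncnc2c(C(=O)Nc3cccc4c3c(Br)nn4Cc3cccnc3)csc12` gives 77 nM while compound 2 `Cc1cccc(Cn2nc(Br)c3c(NC(=O)c4csc5c(N)ncnc45)cccc32)n1` gives 27.5 nM and so holds the lower of the only two numbers available. The gap between them is a 2.8-fold lower number from compound 1 to compound 2 (0.45 log units; beyond the scatter) and it comes with 6-methylpyridin-2-yl in place of pyridin-3-yl on a saturated chain carbon bound to an aromatic nitrogen.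

Compound 3 `CCc1nn(Cc2cccc(C)n2)c2cccc(NC(=O)c3csc4c(N)ncnc34)c12` keeps the (6-methylpyridin-2-yl)methyl group of compound 2 and differs from it by ethyl in place of bromo on an aromatic carbon with ethyl in place of bromo on an aromatic carbon. Among the measured compounds shown here, the one measured step, the modest 2.8-fold lower number from compound 1 to compound 2 (0.45 log units; beyond the scatter), concerns a different place in the molecule. For the measured compounds named here, no measured pair changes the bromo group, so the data give neither a size nor a direction for this swap. In this assay no step beyond the scatter is therefore expected, though with wide uncertainty. The estimate amounts to a 1.2-fold higher number from compound 2 to compound 3 (0.07 log units; within the scatter) as the expected step. For compound 3 the estimated concentration is 32 nM within an expected range from 11 nM to 95 nM for this assay.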

Compound 3, concentration for 50% growth inhibition: > 10000 nM
Compound 3: a limit, no number; the forecaster's own chance of this, stated with the estimate: 2%; middle value at least 310-fold (2.49 log units) from the limit.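

The aromatic carbon next to the ring nitrogen, on the five-membered aromatic ring, had not varied in any earlier pair, and the first change there has a large effect in this assay: ethyl in place of bromo gives an at least 360-fold higher number from compound 2 to compound 3 (2.56 log units; beyond the scatter). This single swap, in which one bromine leaves, two carbons enter and no ring, hydrogen-bond donor or hydrogen-bond acceptor is gained or lost, far exceeds the modest change at the other varied place, a 2.8-fold lower number from compound 1 to compound 2 (0.45 log units; beyond the scatter), so growth inhibition in this series depends much more strongly on this substituent than the earlier pair could show. For compound 3 the result is a limit and not a number, so the step has a lower bound but no exact size: the limit of > 10000 nM in this assay, at which 1 of the 3 values shown sits.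

With bromo and ethyl the only groups shown at this position, it remains open whether the loss is specific to ethyl or extends to other replacements of bromo, such as chloro, methyl or a nitrile. Going by these compounds, it also remains open whether ethyl has the same effect when the pyridin-3-yl group of compound 1 takes the place of the 6-methylpyridin-2-yl group.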